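A few compounds are considered here, and "the series" means these few. Any claim that something is new, unique, unknown or untested is made for them only; others in the source may bear on it.

In a functional assay on A549 cells (Homo sapiens), read by MTT assay, with a stated time of 72 h (on this read-out lower numbers stand for stronger inhibition and higher numbers for weaker inhibition), compound 2 `COc1nc(N)nc2c1c(-c1ccsc1)cn2[C@@H]1O[C@H](CO)[C@@H](O)[C@H]1O` reads > 100000 nM and that is a limit of the assay, not a number. Compound 1 `C#Cc1cn([C@@H]2O[C@H](CO)[C@@H](O)[C@H]2O)c2ncnc(OC)c12` gives 8160 nM in this assay and carries ethynyl on its core. Among the compounds with values here, no step between measured compounds is available in this small set. Compound 3 `C#Cc1cn([C@@H]2O[C@H](CO)[C@@H](O)[C@H]2O)c2nc(N)nc(OC)c12` follows from compound 2 through a single change, ethynyl in place of thiophen-3-yl on an aromatic carbon, counted as ethynyl in place of thiophen-3-yl on an aromatic carbon and sitting two ring bonds from the ring nitrogen. Within the data shown here, the only measured ethynyl example is compound 1 at 8160 nM and on that single value a move toward stronger inhibition is expected in this assay for this change. The estimated step is an at least 8.3-fold lower number from compound 2 to compound 3 (0.92 log units; beyond the scatter) and it remains a wide expectation. The estimate for compound 3 is 12000 nM with an expected range from 2500 nM to 60000 nM.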

Compound 3, half-maximal inhibitory concentration: > 100000 nM
Compound 3: a limit, no number (the forecaster's own chance of this, stated with the estimate: 20%); middle value at least 8.3-fold (0.92 log units) away from the limit.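

Compound 3 reads > 100000 nM in this assay, which is a limit of the assay and not a number, so ethynyl at this position gives no measurable value on the amino-bearing core. With ethynyl held in place, amino in place of hydrogen on an aromatic carbon gives an at least 12-fold higher number from compound 1 to compound 3 (1.08 log units; beyond the scatter), so the weaker inhibition goes with the added amino group in this pair. The steps between compound 2 and compound 3 cannot be read, because both compounds rest on the same ceiling: the limit of > 100000 nM in this assay, at which 2 of the 3 values shown sit.

Ethynyl and thiophen-3-yl therefore remain unranked on the amino-bearing core. Open, as far as these compounds go, is whether any group at this position, such as methyl, an aminomethyl group or a longer alkyne chain, brings that core back to a measurable number.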